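Swapping the fluorine pattern on the phenyl ring

This account rests on a few compounds, and the source may have more. Where it says the series, first, only, none or still open, it means among the compounds named here.

Measured compounds and their values in a functional assay on HEK293 cells with D(4) dopamine receptor (Homo sapiens) as the target, read by FLIPR; on this read-out lower numbers stand for an effect already at smaller amounts and higher numbers for an effect only at larger amounts of compound:
- compound 1, `O/N=C(\CCN1CCN(c2ccccn2)CC1)c1ccccc1`, gives 4.4 nM
- compound 2, `O/N=C(\CCN1CCN(c2ccccn2)CC1)c1ccc(F)cc1`, gives 31 nM
- compound 3, `O/N=C(\CCN1CCN(c2ccccn2)CC1)c1cc(F)cc(F)c1`, gives 19.4 nM

All three share one core and differ only in the fluorine pattern on the phenyl ring attached to the carbon with a double bond to nitrogen. Compound 3 stands second highest of the three numbers in this assay; its nearest neighbour is compound 2, whose number is close enough to sit within the scatter, and the furthest is compound 1, which gave a clearly lower number.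

Compound 4, `O/N=C(\CCN1CCN(c2ccccn2)CC1)c1ccc(F)cc1F`, has not yet been measured. It differs from compound 3 as follows: 2,4-difluorophenyl in place of 3,5-difluorophenyl on a carbon with a double bond to nitrogen. The two compounds thus carry the same atoms, arranged differently on the ring.

Going by the values given here, two measured steps bear on this change. Going from compound 1 to compound 2, adding a single fluorine raised the number: a 7.0-fold higher number from compound 1 to compound 2 (0.85 log units; beyond the scatter). Going from compound 1 to compound 3, two fluorines also raised it: a 4.4-fold higher number from compound 1 to compound 3 (0.64 log units; beyond the scatter). Between compound 2 and compound 3 the step was a 1.6-fold lower number from compound 2 to compound 3 (0.20 log units; within the scatter), so the placement of fluorines mattered little. Compound 4 keeps two fluorines, one of them at the same ring position as in compound 2, so no step beyond the scatter is expected: a 1.3-fold higher number from compound 3 to compound 4 (0.11 log units; within the scatter). The estimate for compound 4 in this assay is 25 nM, with a range from 8 nM to 80 nM.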

Compound 4, half-maximal effective concentration: 8.9 nM
The estimate for compound 4 lay 2.8-fold (0.45 log units) above the measured number; measured number inside the range.
By their numbers in this assay, from the lowest: compound 1; then compound 4; then compounds 3 and 2 (each within the scatter of the next).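

In this assay, rearranging the two fluorines from 3,5-difluorophenyl to 2,4-difluorophenyl leaves the atoms unchanged yet still moves the result beyond the scatter (a 2.2-fold lower number from compound 3 to compound 4 (0.34 log units; beyond the scatter)), so the fluorine pattern at this position can matter, which the close values of compound 2 and compound 3 had not revealed. Fluorine also does not push the number in one direction here: the first fluorine raised it (a 7.0-fold higher number from compound 1 to compound 2 (0.85 log units; beyond the scatter)), whereas the further fluorine that completes the 2,4-difluorophenyl ring lowers it (a 3.5-fold lower number from compound 2 to compound 4 (0.54 log units; beyond the scatter)). Even so, this rearranged ring does not match the plain phenyl (a 2.0-fold higher number from compound 1 to compound 4 (0.31 log units; beyond the scatter)), and compound 1 keeps the lowest number of the four.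

Nothing available here explains why the pattern changes the result. As far as these compounds go, it also remains open whether a chloro or methoxy group on this ring, in place of fluorine, would show the same dependence on pattern.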